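A Fluorobenzyl Analogue Next to an Unreadable Dimethyl Step

The compounds below may be only part of what the source reports. "The series", "measured", "known", "first", "only" and "open" are said of these compounds alone.

Compound 2 `COc1cc(N)c(Cl)cc1NC(=O)C1CCN(Cc2ccc(C)c(C)c2)CC1` gives in a functional assay on the whole organism for antagonist activity, with Mus musculus as the target (a lower number here means that less compound is needed, a higher number that more compound is needed for the effect), only a limit, > 8 mg/kg. Compound 1 `CCCCN1CCC(C(=O)Nc2cc(Cl)c(N)cc2OC)CC1` likewise gives in this assay only a limit, > 10 mg/kg. With both values at limits, the step that the two limits leave unreadable from compound 1 to compound 2 cannot be read in size or direction. Compound 3 `COc1cc(N)c(Cl)cc1NC(=O)C1CCN(Cc2ccc(F)cc2)CC1` differs from compound 2 in one place: 4-fluorophenyl in place of 3,4-dimethylphenyl on a saturated chain carbon bound to an amine nitrogen in a ring. Among the measured compounds shown here, no measured step bears on this change, so its direction is unknown. Compound 3 is expected to give 10 mg/kg, in the range 3 mg/kg to 30 mg/kg. The expected step that the limit leaves unreadable from compound 2 to compound 3 is none beyond the scatter, and a limit is again likely.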

Compound 3, dose for half-maximal effect: 0.6 mg/kg
For compound 3 the middle estimate is 17-fold (1.22 log units) above the measured one; the measured number lies below the stated range.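

At the saturated chain carbon bound to an amine nitrogen in a ring, 4-fluorophenyl in place of 3,4-dimethylphenyl brings an at least 13-fold lower number from compound 2 to compound 3 (1.12 log units; beyond the scatter) in this assay. At the same place, 4-fluorophenyl in place of propyl brings an at least 16-fold lower number from compound 1 to compound 3 (1.22 log units; beyond the scatter). Among the compounds shown here, the earlier step could not be read, so these are the first readable steps at this position, and both give only a minimum size.

The change adds the fluorine and removes both methyl groups at once, so the compounds shown do not separate the two. From the compounds shown here alone, whether an unsubstituted benzyl or a chlorobenzyl group would match compound 3 also stays open.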